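The source may report more compounds than this note shows. Statements on the series, on what has been measured and on what is new or still open speak of the compounds shown alone.

In a functional assay on HeLa cells (Homo sapiens) for cytotoxicity, read by sulforhodamine B assay, with a stated time of 48 h (a lower number here means a stronger inhibitor, a higher number a weaker inhibitor), the measured compounds are:
compound 1 `C=CCOc1ccc(F)cc1C(=O)c1cccnc1` with 93000 nM
compound 2 `C=CCOc1cc(Br)ccc1C(=O)c1cccnc1` with > 100000 nM (a limit)
compound 3 `C=CCOc1ccccc1C(=O)c1cccnc1` with > 100000 nM (a limit)

Compound 2 stands at the limit of > 100000 nM in this assay, at which 2 of the 3 values shown sit, which is a limit and not a number. Compound 4 `O=C(c1cccnc1)c1ccc(Br)cc1O` differs from compound 2 in one place: hydrogen in place of allyl on an oxygen on an aromatic ring. The measured steps replace fluoro or bromo, not allyl. They read an at least 1.0-fold higher number from compound 1 to compound 3 (0.03 log units; that floor lies within the scatter) and a step that the two limits leave unreadable from compound 2 to compound 3, so neither gives a size for this change. No step beyond the scatter is therefore expected in this assay, and no direction can be favoured. The expected step is a number no higher from compound 2 to compound 4 (the limit leaves the size open). Compound 4 is estimated at 100000 nM, with an expected range of 40000 nM to 250000 nM.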

Compound 4, half-maximal inhibitory concentration: 37000 nM
For compound 4 the middle estimate is 2.7-fold (0.43 log units) above the measured one; measured number below the stated range.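

Swapping allyloxy for hydroxy is the first change here that can be read beyond the scatter in this assay (an at least 2.7-fold lower number from compound 2 to compound 4 (0.43 log units; beyond the scatter)). The earlier steps, which put hydrogen in place of fluoro or bromo, cannot be read as a size, so this oxygen is the first place shown where a change moves the number. That step is only a floor, because compound 2 carries a limit and not a number: the limit of > 100000 nM in this assay, at which 2 of the 4 values shown sit.

From the compounds shown here alone, whether a methoxy group or a longer chain on this oxygen behaves like allyl or like hydrogen stays open. So does whether hydroxy gives a similar step when fluoro replaces bromo.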